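Methyl on the anilino ring: compound 3 against compound 2

This account rests on a few compounds, and the source may have more. Where it says the series, first, only, none or still open, it means among the compounds named here.

Measured compounds:
- compound 1 `O=C(C1=C(O)C(=O)N(CCCn2ccnc2)C1c1ccc(Br)cc1)c1ccccc1`: 20000 nM
- compound 2 `O=C(C1=C(Nc2ccccc2)C(=O)N(CCCn2ccnc2)C1c1ccc(Br)cc1)c1ccccc1`: 21200 nM

Both measurements come from a functional assay on NCI-H1299 cells (Homo sapiens) for antiproliferative activity, read by MTT assay, with a stated time of 72 h; on this read-out higher numbers stand for weaker inhibition and lower numbers for stronger inhibition. Among the measured compounds shown here, compound 2 carries the higher of the two numbers, with compound 1 as its only neighbour; the step of a 1.1-fold higher number from compound 1 to compound 2 (0.03 log units; within the scatter) does not separate the two. Compound 2 is therefore neither the more nor the less active of the pair on this evidence.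

Compound 3 `Cc1ccc(NC2=C(C(=O)c3ccccc3)C(c3ccc(Br)cc3)N(CCCn3ccnc3)C2=O)cc1` is not yet measured. It differs from compound 2 by methyl in place of hydrogen on an aromatic carbon.

For the measured compounds named here, no measured step touches this ring: the only step in hand, a 1.1-fold higher number from compound 1 to compound 2 (0.03 log units; within the scatter), exchanges the whole substituent on the double-bonded ring carbon and gives no information on a methyl added to the anilino ring. With nothing to point either way, the working expectation is a step that stays within the scatter, that is a 1.0-fold lower number from compound 2 to compound 3 (0.00 log units; within the scatter) in this assay.

On that basis compound 3 is estimated at 21000 nM in this assay, with a range from 9000 nM to 50000 nM; a value at either end would still not be distinguishable from compound 2.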

Compound 3, half-maximal inhibitory concentration: 25800 nM
Compound 3: the middle estimate sits 1.2-fold (0.09 log units) below what was measured; the measured number falls inside the stated range.
By their numbers in this assay, from the lowest: compounds 1, 2 and 3 (each within the scatter of the next).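

In this assay, among the compounds shown here, methyl in place of hydrogen on an aromatic carbon of the anilino ring, para to a large group, gives a 1.2-fold higher number from compound 2 to compound 3 (0.09 log units; within the scatter); this is the first reading on that ring, and at this place the added methyl does not separate compound 3 from compound 2. Read against the hydroxy compound, the whole exchange gives a 1.3-fold higher number from compound 1 to compound 3 (0.11 log units; within the scatter), so (4-methylphenyl)amino, like anilino, stays within the scatter of compound 1 on the double-bonded ring carbon. No supporting data bear on the reason for this result.

On these data alone, the three compounds show only one small substituent on this ring, so it remains open whether a larger or different group at the same place, such as methoxy, a carboxylic acid or a dimethylamino group, would give a step beyond the scatter. Also open, as far as these compounds go, is whether a change elsewhere on the shared core, such as a carboxylic acid in place of the bromo group, would separate from these values in this assay.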